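Aryl variation on the amine nitrogen of the shared core

This account rests on a few compounds, and the source may have more. Where it says the series, first, only, none or still open, it means among the compounds named here.

Three compounds share one core and differ only in the aryl group on a nitrogen on an aromatic ring. In a functional assay on NCI-H1581 cells (Homo sapiens) for inhibition, read by MTT assay, with a stated time of 48 h, tested at 10 uM (a higher number here means more inhibition at the concentration tested (going by the name of the read-out), a lower number less inhibition), compound 1 `COc1cc(NC(=O)Nc2cc(Nc3cc(Br)ccc3OC)ncn2)cc(OC)c1` gives 23.1%, compound 2 `CCc1cccc(Nc2cc(NC(=O)Nc3cc(OC)cc(OC)c3)ncn2)c1` gives 27.7% and compound 3 `COc1cc(NC(=O)Nc2cc(Nc3cc(C)cc(F)c3)ncn2)cc(OC)c1` gives 28.3%. On the numbers alone compound 3 sits at the top of the three, yet a number 5.2 percentage points higher from compound 1 to compound 3 (within the scatter) and a number 0.6 percentage points higher from compound 2 to compound 3 (within the scatter), like a number 4.6 percentage points higher from compound 1 to compound 2 (within the scatter), fall within the scatter, so the three are not separated. Compound 4 `COc1cc(NC(=O)Nc2cc(Nc3ccc(OC)c(I)c3)ncn2)cc(OC)c1` carries 3-iodo-4-methoxyphenyl in place of 3-fluoro-5-methylphenyl on a nitrogen on an aromatic ring. Every measured step at this position is within the scatter, so no step beyond the scatter is expected here either. For compound 4 in this assay an estimate of 27%, range 15% to 40%, is expected, meaning an expected step of a number 1.3 percentage points lower from compound 3 to compound 4 (within the scatter).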

Compound 4, a percentage reported as inhibition, at one concentration (the size of the read-out at that concentration, not a potency): 43%
For compound 4 the middle estimate is 16 percentage points below the measured one, and the stated range ends below it.
By their numbers in this assay, from the lowest: compounds 1, 2 and 3 (each within the scatter of the next); then compound 4.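

This position is not flat: 3-iodo-4-methoxyphenyl separates from all three earlier aryl groups, with a number 14.7 percentage points higher from compound 3 to compound 4 (beyond the scatter), a number 15.3 percentage points higher from compound 2 to compound 4 (beyond the scatter) and a number 19.9 percentage points higher from compound 1 to compound 4 (beyond the scatter). Carrying a halogen and a methoxy group is not enough on its own, since the 5-bromo-2-methoxyphenyl of compound 1 stays with the lower group. Nothing at hand accounts for this rise.

On these data alone, whether the iodine, the methoxy group or their pairing carries the rise remains open. As far as these compounds go, how an amine or a carboxylic acid on this aryl group would read also remains open.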